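Ring size of the alkoxy group on the shared core

A few compounds are considered here, and "the series" means these few. Any claim that something is new, unique, unknown or untested is made for them only; others in the source may bear on it.

Compound 1, `CC1CCC(Oc2cccc3ccc(N)nc23)C1`, gives 823 nM in an assay on cells with melanin-concentrating hormone receptor 1 (Homo sapiens) as the target, read by radioligand binding; on this read-out higher numbers stand for weaker inhibition and lower numbers for stronger inhibition. Compound 2, `CCOCCOc1cccc2ccc(N)nc12`, gives > 2000 nM in this assay, a limit of the assay rather than a number. Compound 3, `Nc1ccc2cccc(OC3CCCC3)c2n1`, gives > 2000 nM in this assay, again only a limit.

Compound 3 therefore stands at the weak end of what has been measured, with the limit of > 2000 nM in this assay, at which 2 of the 3 values shown sit, marking where it and compound 2 sit. Among the compounds with values here, the one readable step that reaches it is an at least 2.4-fold higher number from compound 1 to compound 3 (0.38 log units; beyond the scatter), so removing the methyl from the saturated ring took the series from a number to a limit. The step that the two limits leave unreadable from compound 2 to compound 3 cannot be sized from two limits.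

Compound 4, `Nc1ccc2cccc(OC3CCC3)c2n1`, differs from compound 3 by cyclobutyl in place of cyclopentyl on an oxygen on an aromatic ring. Within the data shown here, no measured step changes the ring itself, so the bearing of the known steps is indirect; the only sized step, an at least 2.4-fold higher number from compound 1 to compound 3 (0.38 log units; beyond the scatter), moved toward weaker inhibition when the alkoxy group lost carbon. Compound 4 is expected to stay at or near the limit, so no step beyond the scatter is expected. The estimate for compound 4 in this assay is 3500 nM, within 1500 nM to 10000 nM. The step that the limit leaves unreadable from compound 3 to compound 4 is the expected outcome.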

Compound 4, half-maximal inhibitory concentration: > 2000 nM
Compound 4: only a limit was reported; the forecaster's own chance of this, stated with the estimate: 70%; the middle value lies beyond the limit too.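

Going from cyclopentyl to cyclobutyl on the oxygen brings back no readable number in this assay, so the methyl-bearing ring of compound 1 remains the only group at this position with a measured value, and the gap to the smaller ring is an at least 2.4-fold higher number from compound 1 to compound 4 (0.38 log units; beyond the scatter). The steps among compound 2, compound 3 and compound 4 cannot be read, as both ends of each are limits. A four-membered ring, a five-membered ring and the open 2-ethoxyethyl chain now all end at the same limit: the limit of > 2000 nM in this assay, at which 3 of the 4 values shown sit.

From the compounds shown here alone, how far compound 2, compound 3 and compound 4 lie past that limit stays open, and so does any ranking among them. Also open, going by these compounds, is whether the gain seen with the methyl in compound 1 extends to a cyclohexyl ring, a dimethylcyclopentyl group or a methylcyclobutyl group.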